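Swapping nitro for methoxy on a pyrazolopyrimidinone amide

The source may report more compounds than this note shows. Statements on the series, on what has been measured and on what is new or still open speak of the compounds shown alone.

Measured compounds:
- compound 1, `COc1cccc(-c2nc3c(-c4cccc(Cl)c4)n[nH]c3c(=O)n2NC(=O)c2ccccc2)c1`, gives 81.9% in a functional assay on SK-MEL-2 cells (Homo sapiens) for cytotoxicity, read by sulforhodamine B assay, with a stated time of 2 days, tested at 100 uM; on this read-out higher numbers stand for more inhibition at the one concentration tested (going by the name of the read-out) and lower numbers for less inhibition
- compound 2, `O=C(Nn1c(-c2cccc([N+](=O)[O-])c2)nc2c(-c3ccc(Cl)cc3)n[nH]c2c1=O)c1ccccc1`, gives 89% in this assay

Compound 2 has the higher of the two numbers, but its gap to compound 1 lies within the scatter, so the two cannot be ranked. Compound 3, `COc1cccc(-c2nc3c(-c4ccc(Cl)cc4)n[nH]c3c(=O)n2NC(=O)c2ccccc2)c1`, differs from compound 2 by methoxy in place of nitro on an aromatic carbon. Going by the values given here, no measured pair shows this exact change. Compound 1, which gives 81.9%, also carries a methoxy and sits within the scatter of compound 2, so no step beyond the scatter is expected. Compound 3 is estimated at 84%, between 70% and 95%, an expected step of a number 5 percentage points lower from compound 2 to compound 3 (within the scatter).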

Compound 3, a percentage reported as inhibition, at one concentration (the size of the read-out at that concentration, not a potency): 84.9%
Estimate against measurement, compound 3: 0.9 percentage points below; the range from low to high includes it.
By their numbers in this assay, from the lowest: compounds 1, 3 and 2 (each within the scatter of the next).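

In this assay, a direct comparison of 3-nitrophenyl and 3-methoxyphenyl on the same core gives a number 4.1 percentage points lower from compound 2 to compound 3 (within the scatter), so these two groups cannot be told apart at this place. Using 4-chlorophenyl in place of 3-chlorophenyl gives a number 3 percentage points higher from compound 1 to compound 3 (within the scatter), so that change cannot be told apart from no change either. Nothing shown here offers an explanation for either result.

Going by these compounds, whether an amine or a carboxylic acid at the nitro and methoxy place would give a clearly different number remains open. With only one concentration tested, the numbers for compound 1, compound 2 and compound 3 describe the size of the effect at that concentration alone.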